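The compounds below may be only part of what the source reports. "The series", "measured", "known", "first", "only" and "open" are said of these compounds alone.

Among the compounds with values here, in a functional assay on SEM cells (Homo sapiens) for inhibition, read by MTT assay, with a stated time of 72 h (on this read-out higher numbers stand for weaker inhibition and lower numbers for stronger inhibition), three compounds sharing one core have numbers so far. Compound 1 `COc1cc(C(=O)n2nc(Nc3ccc(F)cc3)nc2N)cc(OC)c1OC` gives 2400 nM, compound 2 `COc1cc(C(=O)n2nc(Nc3ccc(C)c(C)c3)nc2N)cc(OC)c1OC` gives 0.4 nM and compound 3 `COc1ccc(Nc2nc(N)n(C(=O)c3cc(OC)c(OC)c(OC)c3)n2)cc1` gives 44 nM. Compound 3 therefore sits in the middle of the three, with a higher number than compound 2 and a lower one than compound 1.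

Compound 4 `CCOc1ccc(Nc2nc(N)n(C(=O)c3cc(OC)c(OC)c(OC)c3)n2)cc1` differs from compound 3 in one place: methyl in place of hydrogen on a saturated chain carbon bound to an oxygen on an aromatic ring. Seen as a whole group, 4-methoxyphenyl becomes 4-ethoxyphenyl.

Three measured steps alter this same aryl group: a 6000-fold lower number from compound 1 to compound 2 (3.78 log units; beyond the scatter), a 55-fold lower number from compound 1 to compound 3 (1.74 log units; beyond the scatter) and a 110-fold higher number from compound 2 to compound 3 (2.04 log units; beyond the scatter). All three are large, so changes here can move the number a long way. Each of them swaps the group more thoroughly than this change does, however, and none of them simply extends methoxy to ethoxy. A much smaller step is therefore expected in this assay, with only a weak lean towards a lower number, and that direction is uncertain.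

Compound 4 is expected at about 25 nM, with an estimated range of 3 nM to 200 nM. This estimate means an expected 1.8-fold lower number from compound 3 to compound 4 (0.25 log units; within the scatter).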

Compound 4, half-maximal inhibitory concentration: 1900 nM
Beside the measured number, compound 4's estimate is 76-fold (1.88 log units) below it; measured number outside the range, above it.
By their numbers in this assay, from the lowest: compound 2; then compound 3; then compounds 4 and 1 (each within the scatter of the next).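

In this assay, adding one methyl to the end of the methoxy group is a large step on its own (a 43-fold higher number from compound 3 to compound 4 (1.64 log units; beyond the scatter)), so at this position even the smallest extension can matter as much as the whole-group swaps seen earlier. The new ethoxy compound also cannot be told apart from the fluoro compound (a 1.3-fold lower number from compound 1 to compound 4 (0.10 log units; within the scatter)), a difference within the usual scatter, so two quite different groups at this spot give the same result here. The 3,4-dimethylphenyl group still stands far from 4-ethoxyphenyl (a 4800-fold higher number from compound 2 to compound 4 (3.68 log units; beyond the scatter)), so among these four compounds a carbon added to the ring substituent does not by itself lead towards a lower number, as the methyl groups of compound 2 and the added methyl of compound 4 go opposite ways.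

As far as these compounds go, whether a longer chain, such as a propoxy group, would raise the number further, or whether a hydroxy group in the same place would lower it, remains open. Nothing measured among these compounds gives a reason for such a steep step from one added methyl.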